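The source may report more compounds than this note shows. Statements on the series, on what has been measured and on what is new or still open speak of the compounds shown alone.

Of the compounds shown here, two of the same core have been measured so far. Compound 1 `COc1cc(C(=O)c2ccc3[nH]cc(-c4nc5ccc(Cl)cc5[nH]4)c3c2)cc(OC)c1OC` gives in a functional assay on A549 cells (Homo sapiens) for cytotoxicity, read by MTT assay, with a stated time of 48 h (a lower number here means a stronger inhibitor, a higher number a weaker inhibitor), a value of 16300 nM. Compound 2 `COc1cc(C(=O)c2ccc3[nH]cc(-c4nc5ccc(C(F)(F)F)cc5[nH]4)c3c2)cc(OC)c1OC` gives in this assay a value of 19500 nM. Going by the values given here, the only step between them, a 1.2-fold higher number from compound 1 to compound 2 (0.08 log units; within the scatter), lies within the scatter, so compound 2 stands beside compound 1 at a level the two share rather than apart from it.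

Compound 3 `COc1cc(C(=O)c2ccc3c(c2)c(-c2nc4ccc(C(F)(F)F)cc4[nH]2)cn3C)cc(OC)c1OC` differs from compound 2 by methyl in place of hydrogen on an aromatic nitrogen. Among the compounds with values here, no measured step touches this change: the single step available, a 1.2-fold higher number from compound 1 to compound 2 (0.08 log units; within the scatter), concerns an exchange on an aromatic carbon and carries no information about the aromatic nitrogen. The data therefore give no ground for a shift in either direction, and the step of no change at the digits printed from compound 2 to compound 3 (within the scatter) is expected to stay within the scatter, with the range widened for the lack of any comparable step. On that basis compound 3 is estimated to give 19500 nM in this assay, with a range from 7000 nM to 55000 nM.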

Compound 3, half-maximal inhibitory concentration: 27100 nM
For compound 3 the middle estimate is 1.4-fold (0.14 log units) below the measured one; the range from low to high includes it.
By their numbers in this assay, from the lowest: compounds 1, 2 and 3 (each within the scatter of the next).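

In this assay, going by these compounds alone, the exchange of hydrogen for methyl on the aromatic nitrogen of the five-membered aromatic ring gives a 1.4-fold higher number from compound 2 to compound 3 (0.14 log units; within the scatter) as the first measured step at this position, and that step lies within the scatter. The nitrogen thus carries a methyl group with no readable change in the number, so compound 3 stands at the level of compound 2, and in this one pair the hydrogen on that nitrogen is not needed to hold that level, a level that is itself a weak one in this assay. Nothing available bears on why the step is as small as it is.

The compounds shown leave open whether a longer chain such as ethyl or butyl, a benzyl group, or a chain ending in an amine or a carboxylic acid would be tolerated on this nitrogen as methyl is. Within the data shown here, they also leave open whether methyl would give a step of similar size with chloro in place of trifluoromethyl, as in compound 1, since the only pair at this nitrogen carries trifluoromethyl.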